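Methoxy to bromo on the core of compound 3

This account rests on a few compounds, and the source may have more. Where it says the series, first, only, none or still open, it means among the compounds named here.

Of the compounds shown here, three have been measured in a functional assay on MIA PaCa-2 cells (Homo sapiens) for cytotoxicity; a lower number here means a stronger inhibitor, a higher number a weaker inhibitor. Compound 1 `COc1ccc(Cn2cc(/C=N\NC(=O)c3c[nH]c4ccccc34)c3cc(OC)ccc32)cc1` gives 30500 nM. Compound 2 `COc1ccc2c(c1)c(/C=N\NC(=O)c1c[nH]c3ccc(Br)cc13)cn2Cc1ccc(Cl)cc1` gives 26300 nM. Compound 3 `COc1ccc2c(c1)c(/C=N\NC(=O)c1c[nH]c3ccccc13)cn2Cc1ccc(Cl)cc1` gives 26700 nM, which is the second highest of the three numbers; its nearest neighbour is compound 2 and its furthest is compound 1, and both gaps lie within the scatter, so no order among the three can be read from the numbers.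

Two single-point changes connect the measured compounds. a 1.1-fold lower number from compound 1 to compound 3 (0.06 log units; within the scatter) is within the scatter, and a 1.0-fold higher number from compound 2 to compound 3 (0.01 log units; within the scatter) is within the scatter as well. In this set, an exchange of one substituent on an aromatic carbon has so far left the read-out where it was.

Compound 4 `O=C(N/N=C\c1cn(Cc2ccc(Cl)cc2)c2ccc(Br)cc12)c1c[nH]c2ccccc12` differs from compound 3 by bromo in place of methoxy on an aromatic carbon. Among the compounds with values here, no measured step exchanges methoxy for bromo at this place. The two steps that have been recorded, both exchanges of a single substituent on an aromatic carbon, were within the scatter, so a step within the scatter is expected here too, in neither direction; the expected step is a 1.0-fold higher number from compound 3 to compound 4 (0.00 log units; within the scatter). Compound 4 is therefore estimated at 27000 nM, with a range from 12000 nM to 60000 nM.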

Compound 4, half-maximal inhibitory concentration: 8700 nM
Beside the measured number, compound 4's estimate is 3.1-fold (0.49 log units) above it, and the stated range ends above it.
By their numbers in this assay, from the lowest: compound 4; then compounds 2, 3 and 1 (each within the scatter of the next).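

Within the data shown here, on the shared core, the place that holds methoxy in compound 3 is the first where exchanging one substituent on an aromatic carbon moves the read-out beyond the scatter in this assay: bromo in place of methoxy gives a 3.1-fold lower number from compound 3 to compound 4 (0.49 log units; beyond the scatter), a modest step towards a stronger inhibitor. The two earlier exchanges, a 1.1-fold lower number from compound 1 to compound 3 (0.06 log units; within the scatter) and a 1.0-fold higher number from compound 2 to compound 3 (0.01 log units; within the scatter), lie at other places on the molecule, so the flat read-out they showed does not extend to this position, and the series is not indifferent to every single-substituent change. Nothing available explains the step at this position.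

The single exchange removes methoxy and introduces bromo together, so the compounds shown cannot separate a gain from bromo from a loss of methoxy, and one step cannot show whether the gain in this assay would grow or vanish with other groups here. Hydrogen or chloro at this place would address that first question, while an amine, a carboxylic acid or a longer chain such as ethoxy would show how widely the position tolerates change.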